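From Tert-Butylphenyl Amide to Methyl-Oxazolyl Amide

This account rests on a few compounds, and the source may have more. Where it says the series, first, only, none or still open, it means among the compounds named here.

Compound 1: `CN(C)c1ccc(C(=O)Nc2cccc(NC(=O)COc3ccc4c(c3)OCCC4=O)c2)cc1`, 85 nM
Compound 2: `CC(C)(C)c1ccc(C(=O)Nc2cccc(NC(=O)COc3ccc4c(=O)ccoc4c3)c2)cc1`, 34 nM

Compound 2 has the lowest of the two numbers; compound 1 is the nearest, and the gap between them lies beyond the scatter. Compound 3, `Cc1cc(C(=O)Nc2cccc(NC(=O)COc3ccc4c(=O)ccoc4c3)c2)no1`, has not been measured. It differs from compound 2 in one place: 5-methyl-1,2-oxazol-3-yl in place of 4-(tert-butyl)phenyl on a carbonyl carbon. Among the compounds with values here, no step between measured compounds matches this change, so its size is judged from compound 2 alone. In an assay on isolated protein for inhibition of Rho-associated protein kinase 2 (Homo sapiens), read by scintillation counting, radiometric assay and 33P incorporation, with a stated time of 40 min, in the presence of a further agent that is not named here (a lower number here means a stronger inhibitor, a higher number a weaker inhibitor), compound 3 is expected to give a higher number, a step of a 2.9-fold higher number from compound 2 to compound 3 (0.47 log units; beyond the scatter) beyond the scatter. Compound 3 is estimated at 100 nM, with a range from 30 nM to 350 nM.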

Compound 3, half-maximal inhibitory concentration: 5 nM
Beside the measured number, compound 3's estimate is 20-fold (1.30 log units) above it, and the stated range ends above it.
By their numbers in this assay, from the lowest: compound 3; then compound 2; then compound 1.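

In this assay, the group on this carbonyl carbon proves open to replacement, with a 6.8-fold lower number from compound 2 to compound 3 (0.83 log units; beyond the scatter) when 5-methyl-1,2-oxazol-3-yl takes the place of 4-(tert-butyl)phenyl. A six-membered aromatic ring of carbon only is therefore not needed here, and the group with fewer heavy atoms gives the lower number of this pair. Nothing available accounts for the size of this step. The compounds shown do not separate the part played by the hetero atoms from that of losing the tert-butyl group. On these data alone, how a pyridine ring or a carboxylic acid would fare on this carbonyl carbon remains open.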